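Compound 1 to compound 4: a 2,4-dichlorophenyl swap

A few compounds are considered here, and "the series" means these few. Any claim that something is new, unique, unknown or untested is made for them only; others in the source may bear on it.

Of the compounds shown here, three sharing one core have been measured so far in a functional assay on SK-MEL-2 cells (Homo sapiens) for inhibition, read by sulforhodamine B assay, with a stated time of 48 h; a higher number here means a weaker inhibitor of growth, a lower number a stronger inhibitor of growth. Compound 1 `O=C(Cc1csc2nc(-c3ccc(Br)cc3)cn12)N/N=C/c1ccccc1` gives 33100 nM here. Compound 2 `O=C(Cc1csc2nc(-c3ccc(Br)cc3)cn12)N/N=C/c1ccccc1O` gives 20900 nM and cannot be told apart from compound 1, as the step of a 1.6-fold lower number from compound 1 to compound 2 (0.20 log units; within the scatter) shows. Compound 3 `COc1cccc(OC)c1/C=N/NC(=O)Cc1csc2nc(-c3ccc(Br)cc3)cn12` gives 89100 nM and stands clear of compound 1, with a 2.7-fold higher number from compound 1 to compound 3 (0.43 log units; beyond the scatter) as the step. Compound 1 therefore sits with compound 2, and compound 3 has the higher number.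

Compound 4 `O=C(Cc1csc2nc(-c3ccc(Br)cc3)cn12)N/N=C/c1ccc(Cl)cc1Cl` is still unmeasured. It carries 2,4-dichlorophenyl in place of phenyl on a carbon with a double bond to nitrogen.

Two measured steps change the group at this same place. The hydroxy change is within the scatter, while the 2,6-dimethoxyphenyl change is modest and upward. The step of a 4.3-fold higher number from compound 2 to compound 3 (0.63 log units; beyond the scatter) is also modest. Among the measured compounds shown here, no chlorine-bearing compound has been measured, so these steps bear on the change only indirectly.

The estimated step in this assay is a 1.1-fold lower number from compound 1 to compound 4 (0.04 log units; within the scatter) and none beyond the scatter is expected. The upper end of the range leaves room for a rise like a 2.7-fold higher number from compound 1 to compound 3 (0.43 log units; beyond the scatter) in the measured series. For compound 4 the estimated value is 30000 nM with 12000 nM to 80000 nM as the expected range.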

Compound 4, concentration for 50% growth inhibition: 72400 nM
Estimate against measurement, compound 4: 2.4-fold (0.38 log units) below; low and high end bracket the measured number.
By their numbers in this assay, from the lowest: compounds 2 and 1 (each within the scatter of the next); then compounds 4 and 3 (each within the scatter of the next).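

In this assay, the step of a 2.2-fold higher number from compound 1 to compound 4 (0.34 log units; beyond the scatter) shows that a rise at this place, on the carbon with a double bond to nitrogen, is not confined to the 2,6-dimethoxyphenyl group, as a phenyl carrying only chlorine also gives one. The 2,4-dichlorophenyl and 2,6-dimethoxyphenyl groups cannot be told apart, with a 1.2-fold lower number from compound 3 to compound 4 (0.09 log units; within the scatter), while a 3.5-fold higher number from compound 2 to compound 4 (0.54 log units; beyond the scatter) sets the 2,4-dichlorophenyl group clear of the 2-hydroxyphenyl group. Across these four compounds, the two groups with two substituents on the phenyl ring both stand clear of phenyl and 2-hydroxyphenyl on the higher side, no compound goes against this, and nothing available explains the rise.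

Whether the rise goes with having two substituents or with these particular groups stays open, as a phenyl carrying a single chlorine or a single methoxy is not among the compounds shown. As far as these compounds go, how a phenyl carrying an amine or a carboxylic acid would read at this place is also open.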